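A 3-fluorophenyl analogue after a limit value

A few compounds are considered here, and "the series" means these few. Any claim that something is new, unique, unknown or untested is made for them only; others in the source may bear on it.

Measured so far in a functional assay on KB cells (Homo sapiens) for antiproliferative activity, read by sulforhodamine B assay, with a stated time of 3 days; on this read-out higher numbers stand for an effect only at larger amounts of compound and lower numbers for an effect already at smaller amounts
Compound 1 (`CCC1=C(O)c2c(oc(-c3ccc(C)cc3)cc2=O)C(CC)(CC)C1=O`) gives 39.2 uM
Compound 2 (`CCC1=C(O)c2c(oc(-c3ccc(COC)cc3)cc2=O)C(CC)(CC)C1=O`) gives only a limit (> 52.4 uM)

Compound 2 stands at the limit of > 52.4 uM in this assay, at which 1 of the 2 values shown sits, and carries no number of its own. The next compound to be tested is compound 3 (`CCC1=C(O)c2c(oc(-c3cccc(F)c3)cc2=O)C(CC)(CC)C1=O`), which has 3-fluorophenyl in place of 4-(methoxymethyl)phenyl on an aromatic carbon next to the ring oxygen (3-fluorophenyl in place of 4-(methoxymethyl)phenyl on an aromatic carbon). Among the measured compounds shown here, only one measured step bears on this change, methoxy in place of hydrogen on a saturated chain carbon (an at least 1.3-fold higher number from compound 1 to compound 2 (0.12 log units; that floor lies within the scatter)), and its floor lies within the scatter. Compound 3 has no methoxy group, and neither does compound 1 (39.2 uM), so a value in that region is expected. For the measured compounds named here, no measured compound carries fluorine, so this expectation is loose. The expected change in this assay is small and towards a lower number (an at least 1.5-fold lower number from compound 2 to compound 3 (0.20 log units; that floor lies within the scatter)). Compound 3 is estimated at 33 uM (expected range 14 uM to 56 uM).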

Compound 3, concentration for half-maximal effect: > 56.2 uM
Compound 3 was reported as a limit (the forecaster's own chance of this, stated with the estimate: 30%); at least 1.7-fold (0.23 log units) between middle value and limit.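

In this assay compound 3 is a second compound that yields only a limit and no number of its own: the limit of > 56.2 uM in this assay, at which 1 of the 3 values shown sits.

Compound 3 carries no methoxy group, so a limit at this position no longer goes only with the 4-(methoxymethyl)phenyl group seen in compound 2. Replacing 4-methylphenyl with 3-fluorophenyl on the aromatic carbon next to the ring oxygen gives an at least 1.4-fold higher number from compound 1 to compound 3 (0.15 log units; that floor lies within the scatter), and this floor says nothing about how large the true step is. Compound 2 and compound 3 both stand as limits, so the step between them cannot be read, and the two aryl groups cannot be ranked against each other.

The compounds shown leave open whether the fluorine itself or its place on the phenyl ring matters, since 3-fluorophenyl differs from the 4-methylphenyl of compound 1 in both the substituent and where it sits. They also leave open what an aminomethyl group or a carboxylic acid would do in place of the methyl of compound 1, and whether any group at this position would give a clearly lower number.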